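A few compounds are considered here, and "the series" means these few. Any claim that something is new, unique, unknown or untested is made for them only; others in the source may bear on it.

Measured so far:
compound 1 `Cc1ccc(Nc2ncc3c(n2)N(C2CC2)C(=O)N(c2cc(NC(=O)c4ccc(C)c(C(F)(F)F)c4)ccc2C)C3)cn1` — 649 nM
compound 2 `Cc1ccc(NC(=O)c2cccc(C(F)(F)F)c2)cc1N1Cc2cnc(NCCO)nc2N(C)C1=O` — 3290 nM
compound 3 `CCN1CCN(C(=O)c2ccc(Nc3ncc4c(n3)N(C)C(=O)N(c3cc(NC(=O)c5cccc(C(F)(F)F)c5)ccc3C)C4)cn2)CC1` — 728 nM

In an ADME assay on BaF3 cells (Mus musculus) for inhibition, read by CellTiter-Glo, with a stated time of 72 h (on this read-out lower numbers stand for stronger inhibition of growth and higher numbers for weaker inhibition of growth), compound 2 gives the highest of the three numbers; compound 3 sits closest, and compound 1 furthest, both beyond the scatter. Compound 4 `Cc1ccc(NC(=O)c2cccc(C(F)(F)F)c2)cc1N1Cc2cnc(NC3CC3)nc2N(C)C1=O` is not yet measured. It differs from compound 2 in one place: cyclopropyl in place of 2-hydroxyethyl on a nitrogen on an aromatic ring. For the measured compounds named here, no measured pair shows this change, so its size is open. The account expects compound 4 to stay near compound 2, with a step of a 1.3-fold lower number from compound 2 to compound 4 (0.12 log units; within the scatter) that is not beyond the scatter, leaning to a slightly lower number. The estimate for compound 4 is 2500 nM, within a range from 800 nM to 8000 nM.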

Compound 4, concentration for 50% growth inhibition: 5060 nM
Compound 4: middle estimate off by 2.0-fold (0.31 log units), on the low side; measured number inside the range.
By their numbers in this assay, from the lowest: compounds 1 and 3 (each within the scatter of the next); then compounds 2 and 4 (each within the scatter of the next).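

In this assay, for the compounds shown here, the step of a 1.5-fold higher number from compound 2 to compound 4 (0.19 log units; within the scatter) is the first reading at this position, and it shows that cyclopropyl can replace 2-hydroxyethyl on this nitrogen without a shift beyond the scatter. In this pair, the hydrogen-bond donor and acceptor counted on 2-hydroxyethyl can go without such a shift. Nothing shown gives a reason for this result. Going by these compounds, whether a morpholine ring, a carboxylic acid or a longer chain at this position would move the number beyond the scatter stays open. So does whether this change reads the same on other parts of the series.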